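Chloro to Bromo at the Para Position of the Phenyl Ring

The source may report more compounds than this note shows. Statements on the series, on what has been measured and on what is new or still open speak of the compounds shown alone.

Measured compounds:
compound 1 `c1ccc(-c2cn3ccnc3c(-c3ccc4ncn(C5CCCCC5)c4c3)n2)cc1` — 39.6%
compound 2 `Clc1ccc(-c2cn3ccnc3c(-c3ccc4ncn(C5CCCCC5)c4c3)n2)cc1` — 14.8%

In a functional assay on LOX IMVI cells (Homo sapiens) for inhibition, read by sulforhodamine B assay, with a stated time of 48 h, tested at 10 uM (on this read-out lower numbers stand for less inhibition and higher numbers for more inhibition at the one concentration tested (going by the name of the read-out)), compound 1 gives 39.6% and compound 2 gives 14.8%. Within the data shown here, compound 2 stands lowest of the two numbers, and the single measured step, a number 24.8 percentage points lower from compound 1 to compound 2 (beyond the scatter), is the only comparison that can be drawn on. Compound 3 `Brc1ccc(-c2cn3ccnc3c(-c3ccc4ncn(C5CCCCC5)c4c3)n2)cc1` has not yet been measured. It differs from compound 2 as follows: bromo in place of chloro on an aromatic carbon. The measured step concerns chloro replacing hydrogen rather than one halogen replacing another, so it bears only loosely on compound 3; it does show that a halogen at this place went with the lower number. The step from compound 2 to compound 3 is therefore expected to be a number 0.2 percentage points higher from compound 2 to compound 3 (within the scatter), which is nothing beyond the scatter. Compound 3 is estimated to show 15%, with a range from 0% to 35%.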

Compound 3, a percentage reported as inhibition, at one concentration (the size of the read-out at that concentration, not a potency): 30.7%
The estimate for compound 3 lay 15.7 percentage points below the measured number; measured number inside the range.
By their numbers in this assay, from the lowest: compound 2; then compounds 3 and 1 (each within the scatter of the next).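

In this assay, the change from 4-chlorophenyl to 4-bromophenyl is not a silent swap: the printed step is a number 15.9 percentage points higher from compound 2 to compound 3 (beyond the scatter), so the two halogens do not behave alike at this place on the ring. Measured against the unsubstituted phenyl, bromo gives a number 8.9 percentage points lower from compound 1 to compound 3 (within the scatter), so the drop seen with chloro is not shared by bromo, and a halogen here does not in itself go with the lower number. Nothing available explains this difference between chloro and bromo.

The compounds shown leave open how fluoro or iodo would read at this place, and whether the pattern is confined to halogens or extends to a methoxy group, an amine or a carboxylic acid. They also leave open how these compounds compare at any other concentration.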